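Ester variation on the oxime: dinitrophenyl to acetoxyphenyl

This account rests on a few compounds, and the source may have more. Where it says the series, first, only, none or still open, it means among the compounds named here.

Compound 2 `COc1ccc(C2CC(=NOC(=O)c3cc([N+](=O)[O-])cc([N+](=O)[O-])c3)CC(c3ccc(OC)cc3)N2C)cc1` carries the highest of the two numbers recorded so far in a functional assay, with a stated time of 30 min; on this read-out higher numbers stand for weaker inhibition and lower numbers for stronger inhibition: compound 2 gives 312000 nM. Its nearest neighbour, compound 1 `COc1ccc(C2CC(=NOC(=O)c3ccc(F)cc3)CC(c3ccc(OC)cc3)N2C)cc1`, gives 152000 nM in this assay. Going by the values given here, the one step between measured compounds, a 2.1-fold higher number from compound 1 to compound 2 (0.31 log units; beyond the scatter), put a 3,5-dinitrophenyl in place of a 4-fluorophenyl on the carbonyl carbon. Compound 3 `COc1ccc(C2CC(=NOC(=O)c3ccccc3OC(C)=O)CC(c3ccc(OC)cc3)N2C)cc1` varies that same ester group again: 2-acetoxyphenyl in place of 3,5-dinitrophenyl on a carbonyl carbon. Among the compounds with values here, the step from compound 1 to compound 2 is the only one bearing on this change, as it alone alters the aryl on the carbonyl carbon, and it was modest; it shows the 3,5-dinitrophenyl giving the weaker of the two numbers seen. A modest movement back, a 1.7-fold lower number from compound 2 to compound 3 (0.24 log units; within the scatter), is therefore expected in this assay. For compound 3 the estimate in this assay is 180000 nM, with a range from 60000 nM to 500000 nM.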

Compound 3, half-maximal inhibitory concentration: 350000 nM
For compound 3 the middle estimate is 1.9-fold (0.29 log units) below the measured one; the measured number falls inside the stated range.
By their numbers in this assay, from the lowest: compound 1; then compounds 2 and 3 (each within the scatter of the next).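

In this assay the exchange of 3,5-dinitrophenyl for 2-acetoxyphenyl on a carbonyl carbon gives a 1.1-fold higher number from compound 2 to compound 3 (0.05 log units; within the scatter) and so does not separate the two groups, although one carries 4 hydrogen-bond acceptors and the other 2. Measured against 4-fluorophenyl, 2-acetoxyphenyl gives a 2.3-fold higher number from compound 1 to compound 3 (0.36 log units; beyond the scatter) and repeats the direction of a 2.1-fold higher number from compound 1 to compound 2 (0.31 log units; beyond the scatter), which leaves compound 1 with the lowest number of the three, by modest steps only. No measured evidence bears on why these groups fall as they do.

Still open, going by these compounds, is whether an aryl ring is needed on this carbonyl carbon at all, as a plain methyl or a longer alkyl chain would show. Also open, on these data alone, is whether a phenyl bearing an amine or a carboxylic acid would move the number further from these values.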